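The compounds below may be only part of what the source reports. "The series", "measured", "known", "first", "only" and "open" are said of these compounds alone.

Measured so far in a functional assay on cells (Homo sapiens) for cytotoxicity; a higher number here means that more compound is tolerated, a lower number that less compound is tolerated:

Compound 1 `O=C1N(CCCCCCCOc2ccc(Br)cc2)CCN1c1ccncc1` — in this assay compound 1 gives > 25000 nM, which is a limit of the measurement rather than a number.
Compound 2 `O=C1N(CCCCCCCOc2ccc(Cl)cc2)CCN1c1ccncc1` — in this assay compound 2 gives > 25000 nM, again a limit rather than a number.
Compound 3 `O=C1N(CCCCCCOc2ccc(Br)cc2)CCN1c1ccccc1` — in this assay compound 3 gives > 25000 nM, also a limit rather than a number.

From compound 1 to compound 2 the change is chloro in place of bromo on an aromatic carbon, and the step it made is a step that the two limits leave unreadable from compound 1 to compound 2. The difference between the core of compound 1 and the core of compound 3 is not broken down here. Compound 4 `O=C1N(CCCCCCOc2ccc(Cl)cc2)CCN1c1ccccc1` has not been measured yet; it differs from compound 3 by chloro in place of bromo on an aromatic carbon, the same change as from compound 1 to compound 2, made at the same place. Within the data shown here, all three values so far sit at one point, as the limit of > 25000 nM in this assay, at which 3 of the 3 values shown sit, shows. On that basis the step that the limit leaves unreadable from compound 3 to compound 4 is expected to be no larger than the earlier one, and compound 4 is estimated at 30000 nM, most likely reported only as a limit again.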

Compound 4, half-maximal cytotoxic concentration: > 25000 nM
Compound 4 was reported as a limit; the forecaster's own chance of this, stated with the estimate: 85%; the middle value does not contradict the limit.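

No step can be read from compound 3 to compound 4, because both results are only limits, not numbers: the limit of > 25000 nM in this assay, at which 4 of the 4 values shown sit.

The compounds shown leave open at what concentration any of them becomes cytotoxic, and whether bromo and chloro differ at all in this assay.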